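A few compounds are considered here, and "the series" means these few. Any claim that something is new, unique, unknown or untested is made for them only; others in the source may bear on it.

In a functional assay on A549 cells (Homo sapiens) for cytotoxicity, read by MTT assay, with a stated time of 72 h (a lower number here means a stronger inhibitor, a higher number a weaker inhibitor), compound 1 (`O=C(N/N=C/c1ccc([N+](=O)[O-])cc1)Nc1cc2c(Nc3ccc(F)c(Cl)c3)ncnc2cc1O[C@H]1CCOC1`) gives 31200 nM, compound 2 (`O=C(N/N=C/c1cc(Br)c(O)c(Br)c1)Nc1cc2c(Nc3ccc(F)c(Cl)c3)ncnc2cc1O[C@H]1CCOC1`) gives 8910 nM and compound 3 (`COc1cc2ncnc(Nc3ccc(F)c(Cl)c3)c2cc1NC(=O)N/N=C/c1ccc([N+](=O)[O-])cc1`) gives 35100 nM. Compound 3 shares the top of this range with compound 1, within the scatter, and stands clearly above compound 2. Compound 4 (`COc1cc2ncnc(Nc3ccc(F)c(Cl)c3)c2cc1NC(=O)N/N=C/c1cc(OC)c(OC)c(OC)c1`) carries 3,4,5-trimethoxyphenyl in place of 4-nitrophenyl on a carbon with a double bond to nitrogen. For the measured compounds named here, the closest precedent replaces the same 4-nitrophenyl with 3,5-dibromo-4-hydroxyphenyl, a 3.5-fold lower number from compound 1 to compound 2 (0.54 log units; beyond the scatter). Methyl in place of oxolan-3-yl made no difference beyond the scatter, a 1.1-fold higher number from compound 1 to compound 3 (0.05 log units; within the scatter), so that precedent may carry over, although the entering group differs. A modest step to a lower number is expected in this assay, a 2.2-fold lower number from compound 3 to compound 4 (0.34 log units; beyond the scatter). Compound 4 is estimated at 16000 nM, with an expected range of 6000 nM to 40000 nM.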

Compound 4, half-maximal inhibitory concentration: 32100 nM
Estimate against measurement, compound 4: 2.0-fold (0.30 log units) below, and the stated range covers the measured number.
By their numbers in this assay, from the lowest: compound 2; then compounds 1, 4 and 3 (each within the scatter of the next).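

Exchanging 4-nitrophenyl for 3,4,5-trimethoxyphenyl on the carbon with a double bond to nitrogen gives a 1.1-fold lower number from compound 3 to compound 4 (0.04 log units; within the scatter) in this assay, so a larger aromatic group at this place does not by itself shift the number. For the compounds shown here, the only step beyond the scatter at this place remains a 3.5-fold lower number from compound 1 to compound 2 (0.54 log units; beyond the scatter) on the oxolan-3-yl series, so the response depends on the entering group. No measured evidence bears on the reason for this result.

From the compounds shown here alone, whether 3,5-dibromo-4-hydroxyphenyl gives a similar step with methyl on the oxygen stays open. So does the effect of an amine or a carboxylic acid on the phenyl ring.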